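This account rests on a few compounds, and the source may have more. Where it says the series, first, only, none or still open, it means among the compounds named here.

Compound 1 `COc1ccc(CNCc2c(OC)cc(Oc3cccc(Nc4ccccc4)c3)cc2OC)cc1` gives 2620 nM in a functional assay on HCT-116 cells (Homo sapiens) for inhibition, read by MTT assay, with a stated time of 72 h; on this read-out lower numbers stand for stronger inhibition and higher numbers for weaker inhibition; compound 2 `COc1cc(Oc2cccc(Nc3ccccc3)c2)cc(OC)c1CNCc1ccc(F)cc1` gives 4220 nM in this assay. Among the compounds with values here, the one step measured so far, a 1.6-fold higher number from compound 1 to compound 2 (0.21 log units; within the scatter), leaves the two numbers within the scatter of each other, so compound 1 stands apart from nothing. Compound 3 `COc1cc(Oc2cccc(Nc3ccccc3)c2)cc(OC)c1CN[C@H](C)c1ccccc1` differs from compound 1 by 1-phenylethyl in place of 4-methoxybenzyl on an amine nitrogen. Within the data shown here, no measured step touches the amine substituent as a whole; the only step known alters a ring substituent and stays within the scatter. A step of similar size is expected here, a 1.1-fold higher number from compound 1 to compound 3 (0.06 log units; within the scatter), with no clear direction. Compound 3 is estimated at 3000 nM, within 1200 nM to 8000 nM.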

Compound 3, half-maximal inhibitory concentration: > 20000 nM
Compound 3 was reported as a limit (the forecaster's own chance of this, stated with the estimate: 5%); at least 6.6-fold (0.82 log units) between middle value and limit.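

On the amine nitrogen, the benzyl groups of compound 1 and compound 2 give way to 1-phenylethyl with an at least 7.6-fold higher number from compound 1 to compound 3 (0.88 log units; beyond the scatter) and an at least 4.7-fold higher number from compound 2 to compound 3 (0.67 log units; beyond the scatter). This position therefore moves the read-out beyond the scatter, which the ring substituent step alone, a 1.6-fold higher number from compound 1 to compound 2 (0.21 log units; within the scatter), did not. Compound 3 is reported only as a limit in this assay: the limit of > 20000 nM in this assay, at which 1 of the 3 values shown sits.

Which part of the change carries the step stays open, since the ring substituent goes and a defined stereocentre enters together. Plain benzyl on this amine nitrogen, or the opposite 1-phenylethyl enantiomer, would separate the two.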